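The source may report more compounds than this note shows. Statements on the series, on what has been measured and on what is new or still open speak of the compounds shown alone.

Compound 1 `Cc1cc2occ(-c3nc(-c4ccccc4)c(-c4ccccc4)n3-c3ccccc3Cl)c(=O)c2cc1Cl` gives 12500 nM
Compound 2 `Cc1cc2occ(-c3nc(-c4ccccc4)c(-c4ccccc4)n3-c3cccc([N+](=O)[O-])c3)c(=O)c2cc1Cl` gives 6250 nM
Compound 3 `Cc1cc2occ(-c3nc(-c4ccccc4)c(-c4ccccc4)n3-c3ccc(Br)cc3)c(=O)c2cc1Cl` gives 25000 nM

All three were measured in a functional assay on A549 cells (Homo sapiens) for inhibition, read by MTT assay, with a stated time of 72 h (on this read-out higher numbers stand for weaker inhibition and lower numbers for stronger inhibition), and differ only in the group on an aromatic nitrogen. Compound 3 reads 25000 nM and is only partly separated from the other two: the modest 4.0-fold higher number from compound 2 to compound 3 (0.60 log units; beyond the scatter) lies beyond the scatter, while a 2.0-fold higher number from compound 1 to compound 3 (0.30 log units; within the scatter) stays within it.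

Compound 4 `Cc1cc2occ(-c3nc(-c4ccccc4)c(-c4ccccc4)n3-c3cccc(Cl)c3)c(=O)c2cc1Cl` has 3-chlorophenyl in place of 4-bromophenyl on an aromatic nitrogen and keeps the rest of the structure. For the measured compounds named here, the measured swaps at this same nitrogen are the only guide. Compound 1 also carries a chlorophenyl group and gives 12500 nM here, and compound 2, with 3-nitrophenyl, gives 6250 nM here. The largest swap so far is the modest one above, and a 2.0-fold lower number from compound 1 to compound 2 (0.30 log units; within the scatter) stays within the scatter, so no large change is expected. The expected 2.0-fold lower number from compound 3 to compound 4 (0.30 log units; within the scatter) is a small drop in the number, no larger than the scatter. Compound 4 is estimated at 12500 nM with an expected range from 5000 nM to 30000 nM on repeat measurement.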

Compound 4, half-maximal inhibitory concentration: 25000 nM
Compound 4: middle estimate off by 2.0-fold (0.30 log units), on the low side; the measured number falls inside the stated range.
By their numbers in this assay, from the lowest: compounds 2, 1, 3 and 4 (each within the scatter of the next, the first and the last beyond it).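

In this assay, the swap of 3-chlorophenyl for 4-bromophenyl on the aromatic nitrogen gives no change at the digits printed from compound 3 to compound 4 (within the scatter), and 3-chlorophenyl in place of 2-chlorophenyl gives a 2.0-fold higher number from compound 1 to compound 4 (0.30 log units; within the scatter), so neither change separates the halogen-bearing compounds 1, 3 and 4 from one another. For the compounds shown here, the one new step that clears the scatter is chloro in place of nitro on an aromatic carbon, a 4.0-fold higher number from compound 2 to compound 4 (0.60 log units; beyond the scatter), which adds a second pair to the earlier gap between compound 2 and compound 3, although compound 2 still stays within the scatter of compound 1, so the nitro group does not set compound 2 apart from all the halogen-bearing compounds. No supporting measurement is available to explain why these numbers fall as they do.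

On these data alone, all four compounds carry a substituted phenyl group on this nitrogen, so the reading of an unsubstituted phenyl group remains open, as does that of a phenyl group bearing an amine or a carboxylic acid. As far as these compounds go, whether a group of either kind would move the number further from the values seen here, in either direction, also remains open.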